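The source may report more compounds than this note shows. Statements on the series, on what has been measured and on what is new or still open speak of the compounds shown alone.

Compound 1 `CCC(Sc1nc2c(cnn2C)c(=O)n1-c1ccccc1)c1ccccc1` gives 179 nM in an assay on isolated protein for inhibition of retinal dehydrogenase 2 (Homo sapiens); on this read-out lower numbers stand for stronger inhibition and higher numbers for weaker inhibition.
Compound 2 `COc1cccc(C(C)Sc2nc3c(cnn3C)c(=O)n2-c2ccccc2)c1` gives 108 nM in this assay.
Compound 3 `CC(Sc1nc2c(cnn2C)c(=O)n1-c1ccccc1)c1cccc(O)c1` gives 100 nM in this assay.

Among these three measured compounds, compound 3 carries the lowest number, but its gaps to the others are small: from compound 1 the step is a 1.8-fold lower number from compound 1 to compound 3 (0.25 log units; within the scatter), and from compound 2 it is a 1.1-fold lower number from compound 2 to compound 3 (0.03 log units; within the scatter). Both lie within the scatter of repeated measurements, so the three compounds cannot be told apart on potency.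

Compound 4 `CC(Sc1nc2c(cnn2C)c(=O)n1-c1ccccc1)c1cncnc1` has not yet been measured. Compared with compound 3, it carries pyrimidin-5-yl in place of 3-hydroxyphenyl on a saturated chain carbon bound to a saturated chain carbon and a sulfur. The two measured steps bear on this change only loosely. They show that swapping a plain phenyl for a hydroxyphenyl, or a methoxy for a hydroxyl, leaves the number in this assay essentially unchanged. Neither step, however, replaces the carbon ring itself with a ring holding two nitrogens, so the present change goes further than anything measured so far.

With no guide beyond the steadiness of the nearby steps, the expectation for compound 4 is a modest drift towards a higher number, a 2.5-fold higher number from compound 3 to compound 4 (0.40 log units; beyond the scatter), with wide uncertainty. Compound 4 is therefore estimated at 250 nM, within a range from 80 nM to 800 nM.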

Compound 4, half-maximal inhibitory concentration: 380 nM
The estimate for compound 4 lay 1.5-fold (0.18 log units) below the measured number, and the stated range covers the measured number.
By their numbers in this assay, from the lowest: compounds 3, 2 and 1 (each within the scatter of the next); then compound 4.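

Until now, the changes at this place stayed within the scatter, but swapping the carbon ring for a ring holding two nitrogens moves the number beyond it in this assay, with a 3.8-fold higher number from compound 3 to compound 4 (0.58 log units; beyond the scatter) and a 3.5-fold higher number from compound 2 to compound 4 (0.55 log units; beyond the scatter) as the two clean comparisons. The third comparison, a 2.1-fold higher number from compound 1 to compound 4 (0.33 log units; beyond the scatter), also lies beyond the scatter and points the same way, although it alters the chain as well as the ring, with 1-(pyrimidin-5-yl)ethyl in place of 1-phenylpropyl on the sulfur, so it cannot be pinned on the ring alone. This position on the saturated chain carbon is therefore sensitive to the identity of the ring, yet the change brings only a modest rise in the number, and nothing measured here accounts for that rise.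

The swap removes the hydroxyl and brings in two ring nitrogens at once, so these compounds cannot show which of the two matters. A pyridine ring with a single nitrogen, or a phenyl ring carrying an amine or a carboxylic acid, would be needed at this place to separate those two parts of the change.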